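Swapping the Piperazine Tail for a Diethylamine Chain

A few compounds are considered here, and "the series" means these few. Any claim that something is new, unique, unknown or untested is made for them only; others in the source may bear on it.

Compound 1, `CN1CCN(CCCOc2c(OCc3ccccc3)cc3oc(-c4ccccc4)cc(=O)c3c2O)CC1`: 1300 nM
Compound 2, `COc1cc2oc(-c3ccccc3)cc(=O)c2c(O)c1OCCCN1CCN(C)CC1`: 18000 nM
Compound 3, `CCN(CC)CCCOc1c(OC)cc2oc(-c3ccccc3)cc(=O)c2c1O`: 4900 nM

In a functional assay on A549 cells (Homo sapiens) for antiproliferative activity, read by MTT assay, with a stated time of 48 h (a higher number here means a weaker inhibitor, a lower number a stronger inhibitor), compound 1 gives the lowest of the three numbers; compound 3 stands nearest to it and compound 2 furthest away. Two single changes connect the measured compounds. Taking away the phenyl gives a 14-fold higher number from compound 1 to compound 2 (1.14 log units; beyond the scatter). Exchanging the cyclic amine for an open one gives a 3.7-fold lower number from compound 2 to compound 3 (0.57 log units; beyond the scatter).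

Compound 4, `CCN(CC)CCCCOc1c(OCc2ccccc2)cc2oc(-c3ccccc3)cc(=O)c2c1O`, keeps the rest of compound 1 and alters only its amine end: (diethylamino)methyl in place of 4-methylpiperazin-1-yl on a saturated chain carbon, three bonds along the chain from an oxygen on an aromatic ring. The second measured step is the one that bears on this change, since the same amine exchange lowered the number from compound 2 to compound 3, although both of those compounds lack the phenyl that compound 1 carries, and the chain there was not lengthened. Among the compounds with values here, no measured pair shows the added chain carbon on its own. A modest drop is therefore expected, a 2.6-fold lower number from compound 1 to compound 4 (0.41 log units; beyond the scatter). Compound 4 is estimated at 500 nM, within a range from 150 nM to 1600 nM.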

Compound 4, half-maximal inhibitory concentration: 1800 nM
Estimate against measurement, compound 4: 3.6-fold (0.56 log units) below; the measured number lies above the stated range.
By their numbers in this assay, from the lowest: compounds 1 and 4 (each within the scatter of the next); then compound 3; then compound 2.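

In this assay, exchanging the amine end on the phenyl-bearing compound gives a 1.4-fold higher number from compound 1 to compound 4 (0.14 log units; within the scatter), so 4-(diethylamino)butyl serves about as well as 3-(4-methylpiperazin-1-yl)propyl at this position. The clear gain from the open amine, a 3.7-fold lower number from compound 2 to compound 3 (0.57 log units; beyond the scatter), therefore does not carry over to compound 4, where the phenyl is present and the chain is longer. Nothing available explains this difference between the two exchanges.

The compounds shown leave open what the amine and the extra chain carbon each contribute, and a 3-(diethylamino)propyl chain on the core of compound 1 would separate the two. As far as these compounds go, whether a ring such as morpholine at the chain end would match these amines also remains open.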